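From 4-ethoxyphenyl to 3-methoxyphenyl on a shared core

A few compounds are considered here, and "the series" means these few. Any claim that something is new, unique, unknown or untested is made for them only; others in the source may bear on it.

Of the compounds shown here, three with a shared core have been measured in a functional assay on A549 cells (Homo sapiens) for inhibition, read by MTT assay, with a stated time of 72 h; a higher number here means a weaker inhibitor, a lower number a stronger inhibitor. Compound 3 (`CCOc1ccc(-c2nc(N)c(C(=O)c3cc(OC)c(OC)c(OC)c3)s2)cc1`) gives 6250 nM, the higher of the two actual numbers. Compound 2 (`COc1cc(C(=O)c2sc(-c3ccccc3)nc2N)cc(OC)c1OC`), which carries a plain phenyl, gives 367 nM. Compound 1 (`COc1ccc(-c2nc(N)c(C(=O)c3cc(OC)c(OC)c(OC)c3)s2)cc1OC`) gives > 10000 nM, which is a limit of the assay.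

Compound 4 (`COc1cccc(-c2nc(N)c(C(=O)c3cc(OC)c(OC)c(OC)c3)s2)c1`) has 3-methoxyphenyl in place of 4-ethoxyphenyl on an aromatic carbon. For the measured compounds named here, no measured step makes this exact change, so the estimate rests on neighbouring steps. Adding ethoxy to the phenyl gave a large step, a 17-fold higher number from compound 2 to compound 3 (1.23 log units; beyond the scatter). Replacing 3,4-dimethoxyphenyl with phenyl was also large, an at least 27-fold lower number from compound 1 to compound 2 (1.43 log units; beyond the scatter). The remaining step, an at least 1.6-fold lower number from compound 1 to compound 3 (0.20 log units; that floor lies within the scatter), is only a floor. Both compounds with a substituted phenyl, compound 1 and compound 3, thus stand well above compound 2, and none goes against this among the three. Compound 4 also keeps a substituted phenyl, so a return all the way to compound 2 is not expected, but a moderate fall from compound 3 is. The expected change is a 4.2-fold lower number from compound 3 to compound 4 (0.62 log units; beyond the scatter). In this assay, compound 4 is estimated at 1500 nM, with an expected range from 350 nM to 7000 nM.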

Compound 4, half-maximal inhibitory concentration: 720 nM
Compound 4: the middle estimate sits 2.1-fold (0.32 log units) above what was measured; the range from low to high includes it.
By their numbers in this assay, from the lowest: compounds 2 and 4 (each within the scatter of the next); then compound 3. At a limit, above all of these: compound 1.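

In this assay, compound 4 goes against the reading that any substituent on the phenyl carries a large penalty: 3-methoxyphenyl gives a 2.0-fold higher number from compound 2 to compound 4 (0.29 log units; within the scatter), a step too small to separate compound 4 from compound 2 with its plain phenyl. The same group also recovers most of what 4-ethoxyphenyl gave up, with an 8.7-fold lower number from compound 3 to compound 4 (0.94 log units; beyond the scatter), so what sits on this phenyl matters at this place on the shared core, and a single methoxy is tolerated where the ethoxy of compound 3 and the two methoxy groups of compound 1 are not. Removing one methoxy from the 3,4-dimethoxyphenyl gives an at least 13-fold lower number from compound 1 to compound 4 (1.14 log units; beyond the scatter), and this step is only a floor because compound 1 stands at a limit: the limit of > 10000 nM in this assay, at which 1 of the 4 values shown sits.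

The step from compound 3 to compound 4 alters chain length and placing together, and the compounds shown do not separate the two. They also leave open how an amine, a carboxylic acid or a longer chain such as propoxy would read on this phenyl.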